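The source may report more compounds than this note shows. Statements on the series, on what has been measured and on what is new or still open speak of the compounds shown alone.

Of the compounds shown here, three have been measured in an ADME assay on the whole organism (plasma, strain Sprague-Dawley) for pharmacokinetics, with Rattus norvegicus as the target, with stated times of 6 h and 30 min, at a dose of 10 mg/kg by the oral route; on this read-out lower numbers stand for lower exposure and higher numbers for higher exposure at the dose given. Compound 1, `CC(C)(C)S(=O)(=O)Nc1ccc(-c2c(C(N)=O)c3cc(F)c(OC(F)F)cc3n2-c2ccccc2)cc1`, gives 7670 ng.h/mL, the highest of the three. Compound 2, `CC(C)(C)S(=O)(=O)Nc1ccc(-c2c(C(N)=O)c3cc(F)c(OC(F)F)cc3n2C2CCCC2)c(F)c1`, gives 200 ng.h/mL, the lowest. Compound 3, `Cc1cc2c(cc1F)c(C(N)=O)c(-c1ccc(NS(=O)(=O)C(C)(C)C)cc1)n2C1CCC1`, gives 664 ng.h/mL, which places it second highest: its nearest neighbour is compound 2, whose number is lower by a gap beyond the usual scatter, and the furthest is compound 1, whose number is higher by a gap that is also beyond the scatter. No two of these compounds differ in only one place, so no single step has been isolated.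

Compound 4, `Cc1cc2c(cc1F)c(C(N)=O)c(-c1ccc(NS(=O)(=O)C(C)(C)C)cc1)n2-c1ccccc1`, has not yet been measured in this assay. It differs from compound 3 by phenyl in place of cyclobutyl on an aromatic nitrogen. Compound 1, which also carries phenyl on that aromatic nitrogen, gives the highest number seen, so the step is expected to go upward, by a 3.8-fold higher number from compound 3 to compound 4 (0.58 log units; beyond the scatter), beyond the scatter. For compound 4 the expected value is 2500 ng.h/mL, between 800 ng.h/mL and 8000 ng.h/mL.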

Compound 4, area under the concentration-time curve: 7140 ng.h/mL
Estimate against measurement, compound 4: 2.9-fold (0.46 log units) below, and the stated range covers the measured number.
By their numbers in this assay, from the lowest: compound 2; then compound 3; then compounds 4 and 1 (each within the scatter of the next).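

In this assay, phenyl in place of cyclobutyl on the aromatic nitrogen gives an 11-fold higher number from compound 3 to compound 4 (1.03 log units; beyond the scatter), the one step shown at this position in which nothing else changes, and it is large. With phenyl on that nitrogen, methyl in place of difluoromethoxy on an aromatic carbon gives a 1.1-fold lower number from compound 1 to compound 4 (0.03 log units; within the scatter), which lies within the scatter, so this read-out does not separate the two groups in this setting. Nothing available explains why the nitrogen substituent matters so much for the read-out.

Going by these compounds, it remains open whether a pyridine ring, or a small alkyl group such as methyl, on that nitrogen would give a number nearer that of compound 3 or that of compound 4. On these data alone, it is also open whether the step from cyclobutyl to phenyl keeps its size in a compound carrying difluoromethoxy.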